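Swapping a Fluorobenzyl Group for Hydroxy in Compound 3

A few compounds are considered here, and "the series" means these few. Any claim that something is new, unique, unknown or untested is made for them only; others in the source may bear on it.

Measured so far in a functional assay on DLD-1 cells (Homo sapiens) for antiproliferative activity, read by CellTiter-Glo, with a stated time of 72 h; on this read-out lower numbers stand for stronger inhibition and higher numbers for weaker inhibition:
compound 1, `Cc1cc(C)c(S(=O)(=O)N2CCC(N3CCCCCC3)CC2)c(C)c1`: 5.3 nM
compound 2, `Cc1cc(C)c(S(=O)(=O)N2CCC(N3CCC(Cc4ccc(F)cc4)CC3)CC2)c(C)c1`: 18 nM

Compound 2 stands at the higher of the two numbers recorded in this assay. Its nearest neighbour is compound 1, whose value of 5.3 nM lies lower by a gap beyond the usual scatter, so compound 1 is the stronger inhibitor of the pair. The two structures differ at the group attached to the six-membered non-aromatic ring, but no single-point comparison among measured compounds exists here, and the gap between them is all the two values show.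

Compound 3, `Cc1cc(C)c(S(=O)(=O)N2CCC(N3CCC(O)CC3)CC2)c(C)c1`, takes the next step from compound 2: hydroxy in place of 4-fluorobenzyl on a saturated ring carbon. Going by the values given here, no measured pair isolates this exchange, so the expectation rests on the change itself rather than on a recorded step. The step from compound 2 to compound 3 in this assay is expected to be a 3.1-fold higher number from compound 2 to compound 3 (0.49 log units; beyond the scatter), a weakening beyond the scatter though not a large one. Compound 3 is accordingly estimated at 55 nM, with a likely range from 14 nM to 220 nM.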

Compound 3, half-maximal inhibitory concentration: 106 nM
For compound 3 the middle estimate is 1.9-fold (0.28 log units) below the measured one, and the stated range covers the measured number.
By their numbers in this assay, from the lowest: compound 1; then compound 2; then compound 3.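

In this assay, going by these compounds alone, the exchange of 4-fluorobenzyl for hydroxy on this saturated ring carbon, three ring bonds from the ring nitrogen, now has a measured size: a 5.9-fold higher number from compound 2 to compound 3 (0.77 log units; beyond the scatter), the first reading at this position that differs in one place only. Compound 3 also gives a second comparison, in which 4-hydroxypiperidin-1-yl in place of azepan-1-yl produces a 20-fold higher number from compound 1 to compound 3 (1.30 log units; beyond the scatter); both steps lie beyond the scatter and leave compound 3 with the highest number of the three, so a small hydroxy group at this position does not retain the strength seen with either of the other two substituents. Nothing available accounts for the size of either step.

The compounds shown leave open whether the weakening follows the loss of 4-fluorobenzyl or the arrival of hydroxy, a question that a plain hydrogen on the same carbon would begin to separate. They also leave open how a methoxy group, an amine, a carboxylic acid or an unsubstituted benzyl group would read at this position, and so whether the hydroxy result extends to any other small group there.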